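The source may report more compounds than this note shows. Statements on the series, on what has been measured and on what is new or still open speak of the compounds shown alone.

Measured in a functional assay on SK-OV-3 cells (Homo sapiens) for inhibition, read by CCK-8 assay, with a stated time of 70 h; on this read-out lower numbers stand for stronger inhibition and higher numbers for weaker inhibition:

compound 1, `Clc1ccc(COc2ccc(OCCOCCNC3CCCC3)cc2)cc1`: 7670 nM
compound 2, `c1ccc(COc2ccc(OCCOCCNc3ccccc3)cc2)cc1`: a limit, > 100000 nM
compound 3, `COc1ccc(COc2ccc(OCCOCCNC3CCCC3)cc2)cc1`: 15700 nM

Compound 1 has the lowest of the two numbers shown. Its nearest neighbour is compound 3, reached by a 2.0-fold higher number from compound 1 to compound 3 (0.31 log units; beyond the scatter). For compound 2 this assay reports only a limit (the limit of > 100000 nM in this assay, at which 1 of the 3 values shown sits).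

Compound 4, `O=[N+]([O-])c1ccc(COc2ccc(OCCOCCNC3CCCC3)cc2)cc1`, differs from compound 1 in one place: nitro in place of chloro on an aromatic carbon. Among the measured compounds shown here, the only measured step that bears on this position is the one from compound 1 to compound 3, a modest one. For the measured compounds named here, no measured pair exchanges chloro for nitro, so the step to compound 4 is expected to stay small, most likely toward a somewhat higher number, as a 1.3-fold higher number from compound 1 to compound 4 (0.12 log units; within the scatter). Compound 4 is therefore estimated at 10000 nM, within 3500 nM to 28000 nM.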

Compound 4, half-maximal inhibitory concentration: 20300 nM
For compound 4 the middle estimate is 2.0-fold (0.31 log units) below the measured one, within the range that was stated.
By their numbers in this assay, from the lowest: compound 1; then compounds 3 and 4 (each within the scatter of the next). At a limit, above all of these: compound 2.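

In this assay, the change from 4-chlorophenyl to 4-nitrophenyl gives a 2.6-fold higher number from compound 1 to compound 4 (0.42 log units; beyond the scatter), so a second replacement of chloro on this aromatic carbon also leads to a higher number. Nitro and methoxy cannot be told apart at this position, with a 1.3-fold higher number from compound 3 to compound 4 (0.11 log units; within the scatter). Nothing shown here gives a reason for either step. Going by these compounds, it remains open how bromo, an amine or a carboxylic acid on this aromatic carbon would read, and whether any group there would match or improve on chloro.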